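The source may report more compounds than this note shows. Statements on the series, on what has been measured and on what is new or still open speak of the compounds shown alone.

In a functional assay on HCT-116 cells (Homo sapiens) for cytotoxicity, read by MTT assay, with a stated time of 48 h, in the presence of a further agent that is not named here (on this read-out higher numbers stand for an effect only at larger amounts of compound and lower numbers for an effect already at smaller amounts), compound 1 (`Cn1ncc2c(-c3ccccc3)cc(NNC(=O)Nc3cc(Cl)nc(Cl)c3)nc21`) gives 6240 nM and compound 2 (`CCCc1cc(NNC(=O)Nc2cc(Cl)nc(Cl)c2)nc2c1cnn2C`) gives 76200 nM, the higher of the two numbers. The next analogue, compound 3 (`CC(C)c1cc(NNC(=O)Nc2cc(Cl)nc(Cl)c2)nc2c1cnn2C`), differs from compound 2 in one group: isopropyl in place of propyl on an aromatic carbon. Among the measured compounds shown here, the only measured step, a 12-fold higher number from compound 1 to compound 2 (1.09 log units; beyond the scatter), was large, but it exchanged phenyl for propyl. Here one chain replaces another of equal size, so a much smaller change is expected in this assay, probably within the scatter and slightly towards lower numbers. The estimated step is a 1.5-fold lower number from compound 2 to compound 3 (0.18 log units; within the scatter). For compound 3 the expected value is 50000 nM, with an estimated range of 17000 nM to 130000 nM.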

Compound 3, half-maximal effective concentration: 17200 nM
For compound 3 the middle estimate is 2.9-fold (0.46 log units) above the measured one; the measured number falls inside the stated range.
By their numbers in this assay, from the lowest: compound 1; then compound 3; then compound 2.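

In this assay the place opposite the ring nitrogen distinguishes between two chains of 3 heavy atoms, so branching alone gives a step beyond the scatter: (a 4.4-fold lower number from compound 2 to compound 3 (0.65 log units; beyond the scatter)). Branching does not make up for the loss of the ring, with (a 2.8-fold higher number from compound 1 to compound 3 (0.44 log units; beyond the scatter)), and compound 1 keeps the lowest number of the three. No measured property is available to account for either step.

Still open, as far as these compounds go, is whether cyclopropyl, a longer branched chain or an amine at this place would fall nearer to isopropyl or to phenyl. Also open, from the compounds shown here alone, is whether a chloro or methoxy group on the phenyl would shift the number of compound 1.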